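Removing One Methoxy Group on a Cinnamate Ester

This account rests on a few compounds, and the source may have more. Where it says the series, first, only, none or still open, it means among the compounds named here.

Measured so far in a functional assay on EA.hy 926 cells (Homo sapiens) for cytotoxicity, read by MTT assay, with stated times of 24 h and 12 h, tested at 100 uM; a higher number here means a stronger effect of the compound at the concentration tested, a lower number a weaker effect:
compound 1, `Cc1nc(C)c(C(=O)Oc2ccccc2/C=C/C(=O)O)nc1C`, gives 80.1%;
compound 2, `COc1ccc(OC(=O)c2nc(C)c(C)nc2C)c(/C=C/C(=O)O)c1`, gives 79.2%;
compound 3, `CCOC(=O)/C=C/c1cc(OC)c(OC(=O)c2nc(C)c(C)nc2C)c(OC)c1`, gives -47%.

Compound 1 and compound 2 share a free carboxylic acid on their side chain, and their two readings in this assay lie close together: the change hydrogen in place of methoxy on an aromatic carbon moves the reading by a number 0.9 percentage points higher from compound 2 to compound 1 (within the scatter). Compound 3 carries an ethyl ester instead of the acid, and its reading falls far beneath both; how its core differs from that of compound 2 is not broken down here.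

Compound 4, `CCOC(=O)/C=C/c1ccc(OC(=O)c2nc(C)c(C)nc2C)c(OC)c1`, is not yet measured. It arises from compound 3 through the same kind of change, (hydrogen in place of methoxy on an aromatic carbon), though the surroundings are not identical: in compound 3 the leaving methoxy sits ortho to a large group and meta to a methoxy group, while in compound 2 it sat para to a large group. Since the earlier step of a number 0.9 percentage points higher from compound 2 to compound 1 (within the scatter) stayed within the scatter, only a small step of a number 12 percentage points higher from compound 3 to compound 4 (beyond the scatter) is expected here, because compound 3 gives -47% and keeps its ester. Compound 4 is therefore estimated at -35%, likely between -75% and 20%.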

Compound 4, a percentage reported as activity, at one concentration (the size of the read-out at that concentration, not a potency): 71.6%
Compound 4: middle estimate off by 106.6 percentage points, on the low side, and the stated range ends below it.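

In this assay, putting hydrogen in place of methoxy on an aromatic carbon gives a number 118.6 percentage points higher from compound 3 to compound 4 (beyond the scatter), so this time the change moves the reading a long way. The effect of this change therefore does not carry over unchanged from one core to another in this series: the same change on two cores in this assay, a number 0.9 percentage points higher (within the scatter) from compound 2 to compound 1 and a number 118.6 percentage points higher (beyond the scatter) from compound 3 to compound 4, 117.7 percentage points apart, beyond the scatter of two such steps This shows that the same swap can do very little on one core and a great deal on another, but it does not show why, since the two pairs differ in more than one feature, including a free carboxylic acid in one and an ethyl ester in the other, and two pairs alone give no rule for any further core.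

Going by these compounds, it stays open whether the same swap on a core with an amide in place of the ethyl ester would give a small step or a large one. Also open, on these data alone, is how the reading would respond if an ethoxy group or a longer chain took the place of the methoxy group.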